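A third propanoyloxy on compound 1

The source may hold more compounds than are shown below. What is called first, only, known or untested is meant among the compounds shown, and "the series" means these compounds.

Measured in a functional assay on MCF7 cells (Homo sapiens) for cytotoxicity, read by MTT assay, with a stated time of 48 h; a lower number here means a stronger inhibitor, a higher number a weaker inhibitor:
- Compound 1 `C=C1CC[C@@H]2[C@](C)(COC(=O)CC)[C@H](OC(=O)CC)CC[C@@]2(C)[C@@H]1CCc1ccoc1`: > 100000 nM
- Compound 2 `C=C1CC[C@@H]2[C@](C)(COC(=O)C(Cl)Cl)[C@H](OC(=O)C(Cl)Cl)CC[C@@]2(C)[C@@H]1CCc1ccoc1`: 22900 nM
- Compound 3 `C=C1[C@H](O)C[C@@H]2[C@](C)(COC(=O)CC)[C@H](OC(=O)CC)CC[C@@]2(C)[C@@H]1CCc1ccoc1`: 44000 nM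

Compound 1 gives only a limit, > 100000 nM, and no number. Compound 4 `C=C1CC[C@@H]2[C@](C)(COC(=O)CC)[C@H](OC(=O)CC)CC[C@@]2(C)[C@@H]1CC(OC(=O)CC)c1ccoc1` differs from compound 1 by propanoyloxy in place of hydrogen on a saturated chain carbon bound to an aromatic carbon and a saturated chain carbon, with propanoyloxy in place of hydrogen on a saturated chain carbon bound to an aromatic carbon and a saturated chain carbon. Within the data shown here, the one measured step that bears on this is an at least 2.2-fold lower number from compound 1 to compound 3 (0.35 log units; beyond the scatter), for hydroxy in place of hydrogen on a saturated ring carbon. It involves another group at another kind of carbon, so it is only a loose guide. A modest move toward lower numbers in this assay is therefore expected. The estimated step is an at least 1.6-fold lower number from compound 1 to compound 4 (0.22 log units; that floor lies within the scatter). For compound 4 the expected value is 60000 nM, with an estimated range of 25000 nM to 100000 nM.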

Compound 4, half-maximal inhibitory concentration: > 100000 nM
Compound 4: a limit, no number; the forecaster's own chance of this, stated with the estimate: 40%; at least 1.6-fold (0.22 log units) between middle value and limit.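

Compound 1 and compound 4 both end at a limit and give no number, so no step between them can be read: the limit of > 100000 nM in this assay, at which 2 of the 4 values shown sit.

The compounds shown leave open what propanoyloxy in place of hydrogen on this saturated chain carbon does to the value.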